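Semicarbazone series: phenol to methyl ether on the aryl ring

The compounds below may be only part of what the source reports. "The series", "measured", "known", "first", "only" and "open" are said of these compounds alone.

Measured so far:
compound 1 `O=C(N/N=C/c1ccc(O)cc1)Nc1cccc2ccccc12` — 100 mg/kg
compound 2 `C/C(=N\NC(=O)Nc1cccc2ccccc12)c1ccccc1` — 300 mg/kg

In a functional assay on the whole organism (strain Swiss albino) with Mus musculus as the target, in the maximal electroshock model, with a stated time of 0.5 h (on this read-out higher numbers stand for an effect only at larger amounts of compound and lower numbers for an effect already at smaller amounts), compound 1 gives 100 mg/kg and holds the lowest number of the two; compound 2 gives 300 mg/kg, a higher number, and the gap between the two lies beyond the scatter. Within the data shown here, compound 2 differs from compound 1 in more than one place, so no single step between them is counted.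

Compound 3 `COc1ccc(/C=N/NC(=O)Nc2cccc3ccccc23)cc1` is not yet measured in this assay. It differs from compound 1 by methyl in place of hydrogen on an oxygen on an aromatic ring: the hydroxy on the aromatic ring becomes methoxy.

With no measured step of this kind in the series, the expectation rests on compound 1 alone. The step of a 1.5-fold higher number from compound 1 to compound 3 (0.18 log units; within the scatter) is expected to stay within the scatter or reach a little beyond it, toward a higher number. Compound 3 is therefore estimated at 150 mg/kg, with a range from 60 mg/kg to 300 mg/kg.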

Compound 3, minimum effective dose: 300 mg/kg
For compound 3 the middle estimate is 2.0-fold (0.30 log units) below the measured one, and the stated range covers the measured number.
By their numbers in this assay, from the lowest: compound 1; then compounds 2 and 3 (each within the scatter of the next).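

In this assay, among these compounds, this is the first single-place step: the change from hydroxy to methoxy on the 4-hydroxyphenyl gives a 3.0-fold higher number from compound 1 to compound 3 (0.48 log units; beyond the scatter), a modest step beyond the scatter. At this position, therefore, methyl in place of hydrogen on the oxygen means that an effect appears only at a larger amount of compound, with the rest of the structure unchanged. No measurement at hand explains the step, and this single pair shows no general trend.

On these data alone, it remains open whether the oxygen's hydrogen matters or whether any larger group on that oxygen gives a similar result, which an ethoxy or longer alkoxy chain would test. An amine or a carboxylic acid in place of the hydroxy, or a plain phenyl with only hydrogen at this position, would show how far the position tolerates other groups.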